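This account rests on a few compounds, and the source may have more. Where it says the series, first, only, none or still open, it means among the compounds named here.

Measured so far:
- Compound 1, `COC(=O)c1ccc(OCCCCOc2ccc(C(=O)CC3CCCC3)c(O)c2C)cc1`: "not determined" (no result reported) in an assay on HEK293 cells for positive allosteric modulation of metabotropic glutamate receptor 2 (Rattus norvegicus), read by thallium flux, with a stated time of 2.5 min; a lower number here means that less compound is needed, a higher number that more compound is needed for the effect
- Compound 2, `Cc1c(OCCCCOc2ccc(C(=O)O)cc2F)ccc(C(=O)CC(C)C)c1O`: 102 nM
- Compound 3, `COC(=O)c1ccc(OCCCCOc2ccc(C(=O)CC(C)C)c(O)c2C)cc1`: "not determined" (no result reported) in this assay

Compound 3 stands without a number in this assay; the same holds for compound 1, so nothing can be said about the ester members of the set from the readings themselves. Only compound 2, which carries a carboxylic acid on its second ring, gives a figure in this assay, namely 102 nM.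

Compound 4, `Cc1ccc(C(=O)O)cc1OCCCCOc1ccc(C(=O)CC(C)C)c(O)c1C`, differs from compound 3 in a single place: 5-carboxy-2-methylphenyl in place of 4-(methoxycarbonyl)phenyl on an oxygen on a saturated carbon. The ester gives way to a free acid, and a methyl joins the same ring. Going by the values given here, no step between two measured compounds connects this change to a number, so the size and the direction of the step in this assay from compound 3 to compound 4 cannot be taken from the data; it may equally well lie within the scatter or beyond it, and no expectation of direction rests on firm ground.

The estimate for compound 4 therefore leans on compound 2, which also carries a carboxylic acid and gives 102 nM. On that basis compound 4 is expected to give about 150 nM in this assay, with a range from 40 nM to 600 nM.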

Compound 4, half-maximal effective concentration: 454 nM
Compound 4: the middle estimate sits 3.0-fold (0.48 log units) below what was measured, within the range that was stated.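

In this assay, keeping the carboxylic acid but placing 5-carboxy-2-methylphenyl where 4-carboxy-2-fluorophenyl stood, on an oxygen on a saturated carbon, gives a 4.5-fold higher number from compound 2 to compound 4 (0.65 log units; beyond the scatter), so more compound is needed for the effect. The group at this place therefore matters beyond the mere presence of a free acid, although this single step joins the exchange of fluoro for methyl with a shift in where the carboxy group stands on the ring, and it cannot tell these two changes apart. Nothing at hand gives a measured reason for the step.

Going by these compounds alone, compound 1 and compound 3 have no number, so no step involving either ester can be read, and the effect of replacing the methyl ester with the free acid remains unknown. On these data alone, it also remains open how a plain 4-carboxyphenyl group, a chloro group in place of the fluoro or methyl, or a tetrazole in place of the carboxylic acid would read at this place.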